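Methoxy in Place of Isopropyl: Estimating Compound 4

This account rests on a few compounds, and the source may have more. Where it says the series, first, only, none or still open, it means among the compounds named here.

Compound 1, `Clc1ccc(-c2nc3occn3c2/C=N/OCc2ccc(Cl)c(Cl)c2)cc1`: 410 nM
Compound 2, `Clc1ccc(CO/N=C/c2c(-c3ccc4ccccc4c3)nc3occn23)c(Cl)c1`: 1500 nM
Compound 3, `CC(C)c1ccc(-c2nc3sccn3c2/C=N/OCc2ccc(Cl)c(Cl)c2)cc1`: 590 nM

All three numbers come from an assay on HepG2 cells for agonist activity at nuclear receptor subfamily 1 group I member 3 (Homo sapiens), read by a luciferase reporter, with a stated time of 23 h; a lower number here means that less compound is needed, a higher number that more compound is needed for the effect. Among them compound 3 holds the second highest number. Its nearest neighbour is compound 1, whose number is within the scatter of that of compound 3, so the two cannot be told apart; the furthest is compound 2, which gives a higher number than compound 3 by a margin beyond the scatter.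

The new entry is compound 4, `COc1ccc(-c2nc3sccn3c2/C=N/OCc2ccc(Cl)c(Cl)c2)cc1`. It differs from compound 3 in one place: methoxy in place of isopropyl on an aromatic carbon. Going by the values given here, no pair among the measured compounds shows this change, so nothing here tells how it plays out in this assay.

With that in mind the expectation for a 1.4-fold higher number from compound 3 to compound 4 (0.13 log units; within the scatter) is a step of modest size toward a higher number, one that may not rise beyond the scatter. Compound 4 is accordingly estimated at 800 nM in this assay, with a range from 300 nM to 2500 nM.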

Compound 4, half-maximal effective concentration: 490 nM
Compound 4: the middle estimate sits 1.6-fold (0.21 log units) above what was measured; the range from low to high includes it.
By their numbers in this assay, from the lowest: compounds 1, 4 and 3 (each within the scatter of the next); then compound 2.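

Going by these compounds alone, the step gives the first reading of this change: in this assay, going from 4-isopropylphenyl to 4-methoxyphenyl on the shared core gives a 1.2-fold lower number from compound 3 to compound 4 (0.08 log units; within the scatter) and so leaves the two compounds indistinguishable. At this place, on an aromatic carbon para to a large group, isopropyl with its 3 heavy atoms and 0 hydrogen-bond acceptors can thus give way to methoxy with its 2 heavy atoms and 1 hydrogen-bond acceptor, with no difference that this assay can resolve in this one pair. Nothing available bears on why the two numbers stay together, so the result remains an observation without an explanation.

Whether the same swap reads the same way on the core of compound 1 rests on no pair shown, as this single step is the only reading of it. Also open, going by these compounds, is how other groups at this place would compare with compound 3 and compound 4, for instance an amine, a carboxylic acid or a longer chain such as butoxy.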